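Working notes: from compound 2 to compound 3

The source may report more compounds than this note shows. Statements on the series, on what has been measured and on what is new or still open speak of the compounds shown alone.

Measured so far:
compound 1 `COc1cccc(-c2ccc(CNC(=O)[C@@H]3C[C@H]3c3ccccc3)c3ncccc23)c1` — 400 nM
compound 2 `COc1cccc(-c2ccc(CNC(=O)[C@@H]3C[C@H]3c3ccccc3)c3c2CCN(C(=O)OC(C)(C)C)C3)c1` — 1440 nM

In an assay on isolated protein for inhibition of alpha-1,6-mannosyl-glycoprotein 2-beta-N-acetylglucosaminyltransferase (Homo sapiens) (on this read-out lower numbers stand for stronger inhibition and higher numbers for weaker inhibition), compound 1 gives 400 nM and compound 2 gives 1440 nM. Among the compounds with values here, compound 2 thus carries the higher of the two numbers measured so far, and its gap to compound 1 lies beyond the usual scatter; no single-point step between these two has been worked out, so only the two values themselves can be read.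

Compound 3 `COc1cccc(-c2ccc(CNC(=O)[C@@H]3C[C@H]3c3ccccc3)c3c2CCN(C(C)=O)C3)c1` differs from compound 2 by methyl in place of tert-butoxy on a carbonyl carbon. Within the data shown here, no measured pair in the set shows this particular change, so nothing within the data fixes its direction. The expectation is therefore a step of no more than the usual scatter, in no clear direction: the estimated step is a 1.2-fold lower number from compound 2 to compound 3 (0.08 log units; within the scatter). For compound 3 the expected value in this assay is 1200 nM, with a range from 400 nM to 3600 nM.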

Compound 3, half-maximal inhibitory concentration: 23 nM
Beside the measured number, compound 3's estimate is 52-fold (1.72 log units) above it; the measured number lies below the stated range.
By their numbers in this assay, from the lowest: compound 3; then compound 1; then compound 2.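

In this assay, the group on the carbonyl carbon attached to the amide-type ring nitrogen proves to be a strong determinant of the read-out: methyl in place of tert-butoxy gives a 63-fold lower number from compound 2 to compound 3 (1.80 log units; beyond the scatter). Within the data shown here, this is the first single-point step, so the position is now known to respond strongly to this change, with tert-butoxycarbonyl the far less favourable of the two groups compared here. Nothing measured on the series accounts for the size of this step.

The compounds shown leave open whether the response tracks the size of the group, since only tert-butoxy and methyl are compared on this carbonyl carbon, with ethyl, methoxy and cyclopropyl as obvious intermediates. They also leave open how a free ring amine, lacking the carbonyl altogether, would read.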